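Morpholine for Thiomorpholine: Effect on Growth Inhibition

A few compounds are considered here, and "the series" means these few. Any claim that something is new, unique, unknown or untested is made for them only; others in the source may bear on it.

Measured so far, in a functional assay on MCF7 cells (Homo sapiens) for cytotoxicity, read by MTT assay, with a stated time of 72 h, tested at 10 uM; a lower number here means less inhibition of growth, a higher number more inhibition of growth at the concentration tested:
compound 1, `Cc1ccnc(/C(N)=N/NC(=S)N2CCOCC2)c1`, gives 6.86%;
compound 2, `Cc1ccnc(/C(N)=N/NC(=S)N2CCSCC2)c1`, gives 62.5%;
compound 3, `N/C(=N\NC(=S)N1CCSCC1)c1ccc(F)cn1`, gives 38.1%.

Compound 1 and compound 2 share a core and differ in one place: morpholin-4-yl in place of thiomorpholin-4-yl on a thiocarbonyl carbon. That single swap gave a number 55.6 percentage points lower from compound 2 to compound 1 (beyond the scatter), a large drop in growth inhibition. Compound 3 carries a different core; how the two cores differ is not broken down here. In this assay compound 3 sits lower than compound 2, and that gap lies beyond the scatter.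

Compound 4, `N/C(=N\NC(=S)N1CCOCC1)c1ccc(F)cn1`, is not yet measured. It relates to compound 3 as compound 1 relates to compound 2: morpholin-4-yl in place of thiomorpholin-4-yl on a thiocarbonyl carbon. The place is the same in both pairs, a thiocarbonyl carbon whose other neighbour is an amide-type nitrogen, so this is the same change on a different core. Because compound 3 starts at 38.1% and the earlier step was a number 55.6 percentage points lower from compound 2 to compound 1 (beyond the scatter), a large drop in growth inhibition is expected, roughly a number 32.1 percentage points lower from compound 3 to compound 4 (beyond the scatter). Compound 4 is therefore estimated at 6%, likely between 0% and 25%.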

Compound 4, percent growth inhibition at one concentration: 39.5%
Estimate against measurement, compound 4: 33.5 percentage points below; the measured number lies above the stated range.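

Morpholin-4-yl in place of thiomorpholin-4-yl on a thiocarbonyl carbon gave a number 1.4 percentage points higher from compound 3 to compound 4 (within the scatter) in this assay, so the large drop seen on the core of compound 1 and compound 2 did not appear on this second core. The effect of this swap therefore cannot be carried unchanged from one core to the other, as the two steps set side by side show: the same change on two cores in this assay, a number 55.6 percentage points lower (beyond the scatter) from compound 2 to compound 1 and a number 1.4 percentage points higher (within the scatter) from compound 3 to compound 4, 57 percentage points apart, beyond the scatter of two such steps This does not show which difference between the two cores is responsible, and two pairs give no rule for predicting the swap on any further core.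

The compounds shown leave open how other groups on the thiocarbonyl carbon would behave on either core, for example piperidin-1-yl or a dimethylamino group. They also leave open whether the contrast between the two pairs would hold at other concentrations or in other cell lines, given that every number here comes from a single test condition.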